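A few compounds are considered here, and "the series" means these few. Any claim that something is new, unique, unknown or untested is made for them only; others in the source may bear on it.

Of the compounds shown here, three sharing one core have been tested in a functional assay on A549 cells (Homo sapiens) for cytotoxicity, read by MTT assay, with a stated time of 72 h; a lower number here means a stronger inhibitor, a higher number a weaker inhibitor. Compound 1 `COc1cc2c(Oc3ccc(NC(=O)c4nnn(-c5ccc(F)c(F)c5)c4C(F)(F)F)cc3F)ccnc2cc1OCCCN1CCCCC1` gives 160 nM. Compound 2 `COc1cc2c(Oc3ccc(NC(=O)c4nnn(-c5ccc(C)cc5)c4C(F)(F)F)cc3F)ccnc2cc1OCCCN1CCC(C)CC1` gives 400 nM. Compound 3 `COc1cc2c(Oc3ccc(NC(=O)c4nnn(-c5ccc(F)c(F)c5)c4C(F)(F)F)cc3F)ccnc2cc1OCCCN1CCC(C)CC1` gives 140 nM, the lowest of the three numbers, although its gap to compound 1 lies within the scatter. Between them stand two steps: a 1.1-fold lower number from compound 1 to compound 3 (0.06 log units; within the scatter), and a 2.9-fold lower number from compound 2 to compound 3 (0.46 log units; beyond the scatter). Compound 4 `COc1cc2c(Oc3ccc(NC(=O)c4nnn(-c5ccc(F)c(F)c5)c4C(F)(F)F)cc3F)ccnc2cc1OCCCN1CCN(C)CC1` differs from compound 3 by 4-methylpiperazin-1-yl in place of 4-methylpiperidin-1-yl on a saturated chain carbon, three bonds along the chain from an oxygen on an aromatic ring. Among the compounds with values here, only the first of those steps touches the same ring, and it stayed within the scatter; no measured step swaps one ring for another at that place. The expected step is therefore a 1.1-fold higher number from compound 3 to compound 4 (0.03 log units; within the scatter), within the scatter. Compound 4 is estimated at 150 nM, between 70 nM and 320 nM.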

Compound 4, half-maximal inhibitory concentration: 130 nM
Compound 4: the middle estimate sits 1.2-fold (0.06 log units) above what was measured; the measured number falls inside the stated range.
By their numbers in this assay, from the lowest: compounds 4, 3 and 1 (each within the scatter of the next); then compound 2.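

Within the data shown here, the first swap of one ring for another at this place, 4-methylpiperazin-1-yl in place of 4-methylpiperidin-1-yl, gives a 1.1-fold lower number from compound 3 to compound 4 (0.03 log units; within the scatter). Against piperidin-1-yl the same ring gives a 1.2-fold lower number from compound 1 to compound 4 (0.09 log units; within the scatter), so all three rings read alike here, and a second ring nitrogen leaves the number within the scatter. No evidence is at hand to explain this result. Still open, from the compounds shown here alone, is whether a morpholin-4-yl ring, an open-chain dimethylamino group or a shorter chain would read the same. Also open, going by these compounds, is whether 4-methylpiperazin-1-yl behaves alike with the 4-methylphenyl group of compound 2.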